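Sulfonyl in Place of Acyl on the Amine Nitrogen

The compounds below may be only part of what the source reports. "The series", "measured", "known", "first", "only" and "open" are said of these compounds alone.

Compound 1, `CCCCCCCCCCCCCCCCCCNC(=O)[C@@H](N)[C@@H](C)O`: 39500 nM
Compound 2, `CCCCCCCCCCCCCCCCCCNC(=O)[C@@H](NC(=O)c1cc2ccccc2n1C)[C@@H](C)O`: 113000 nM

Of the compounds shown here, two have been measured so far, both built on the core of compound 1 with a long saturated chain joined through the amide. In a functional assay on SiHa cells (Homo sapiens) for cytotoxicity, read by MTT assay, with a stated time of 48 h (on this read-out lower numbers stand for stronger inhibition and higher numbers for weaker inhibition), compound 1 gives 39500 nM, while compound 2 gives 113000 nM. Among the compounds with values here, compound 2 therefore stands at the higher of the two numbers, and the single measured step, a 2.9-fold higher number from compound 1 to compound 2 (0.46 log units; beyond the scatter), shows that capping the amine nitrogen with the indolylcarbonyl group weakened inhibition modestly.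

Compound 3, `CCCCCCCCCCCCCCCCCCNC(=O)[C@@H](NS(=O)(=O)c1ccc(C)cc1)[C@@H](C)O`, keeps the chain and the core but carries a different cap: (4-methylphenyl)sulfonyl in place of (1-methyl-1H-indol-2-yl)carbonyl on an amine nitrogen. Within the data shown here, no measured step swaps one cap for another on this nitrogen; the only step available, a 2.9-fold higher number from compound 1 to compound 2 (0.46 log units; beyond the scatter), concerns the addition of a cap to a bare amine, so it bears on the new change only loosely. With both caps of similar size and the same count of hydrogen-bond acceptors, the expected step is a 1.1-fold lower number from compound 2 to compound 3 (0.05 log units; within the scatter), that is, nothing beyond the scatter in either direction. Compound 3 is accordingly estimated at 100000 nM, with a range from 40000 nM to 250000 nM.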

Compound 3, half-maximal inhibitory concentration: 29800 nM
Beside the measured number, compound 3's estimate is 3.4-fold (0.53 log units) above it; measured number outside the range, below it.
By their numbers in this assay, from the lowest: compounds 3 and 1 (each within the scatter of the next); then compound 2.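

In this assay, the identity of the cap on this amine nitrogen matters: (4-methylphenyl)sulfonyl in place of (1-methyl-1H-indol-2-yl)carbonyl gives a 3.8-fold lower number from compound 2 to compound 3 (0.58 log units; beyond the scatter) even though the two groups match in their counts of hydrogen-bond donors and acceptors. Measured against the bare amine, the same sulfonyl cap gives a 1.3-fold lower number from compound 1 to compound 3 (0.12 log units; within the scatter) and stays within the scatter, so the two compounds stand level. Capping this nitrogen therefore does not raise the number in itself, and the earlier rise belongs to the (1-methyl-1H-indol-2-yl)carbonyl cap rather than to both caps shown; no measurement offered here accounts for the difference between them.

From the compounds shown here alone, it remains open whether the sulfonyl link or the aromatic part of the cap carries the difference, a question that a benzoyl cap or a methanesulfonyl cap on the same nitrogen would begin to separate. Going by these compounds, it is also open whether the gap between the two caps would persist with a shorter saturated chain in place of the long one.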